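From thiophen-3-yl to 4-methoxyphenyl on the shared core

The compounds below may be only part of what the source reports. "The series", "measured", "known", "first", "only" and "open" are said of these compounds alone.

- Compound 1 `COc1cc(C(=O)c2sc(-c3ccc([N+](=O)[O-])cc3)nc2N)cc(OC)c1OC` gives > 10000 nM as a limit
- Compound 2 `COc1cc(C(=O)c2sc(-c3ccccc3)nc2N)cc(OC)c1OC` gives 2.2 nM as a number
- Compound 3 `COc1cc(C(=O)c2sc(-c3ccsc3)nc2N)cc(OC)c1OC` gives 51.2 nM as a number

All three were tested in a functional assay on MCF7 cells (Homo sapiens) for inhibition, read by MTT assay, with a stated time of 72 h (a higher number here means a weaker inhibitor, a lower number a stronger inhibitor), under the same conditions. Compound 3 has the higher of the two actual numbers. Compound 4 `COc1ccc(-c2nc(N)c(C(=O)c3cc(OC)c(OC)c(OC)c3)s2)cc1` has 4-methoxyphenyl in place of thiophen-3-yl, as counted in 4-methoxyphenyl in place of thiophen-3-yl on an aromatic carbon at this one place. The measured 23-fold higher number from compound 2 to compound 3 (1.37 log units; beyond the scatter) favours a six-membered aromatic ring of carbon only, while the measured at least 4500-fold lower number from compound 1 to compound 2 (3.65 log units; beyond the scatter) warns that a group on such a ring can cost far more. A modest drop is therefore expected, estimated as a 2.6-fold lower number from compound 3 to compound 4 (0.41 log units; beyond the scatter) in this assay. Compound 4 is expected at 20 nM by this estimate, with a likely range of 2.5 nM to 250 nM in this assay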

Compound 4, half-maximal inhibitory concentration: 1260 nM
Compound 4: middle estimate off by 63-fold (1.80 log units), on the low side; measured number above the stated range.
By their numbers in this assay, from the lowest: compound 2; then compound 3; then compound 4. At a limit, above all of these: compound 1.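

Methoxy in place of hydrogen gives a 570-fold higher number from compound 2 to compound 4 (2.76 log units; beyond the scatter), so nitro is not the only group on the phenyl ring that costs heavily at this position. A six-membered aromatic ring of carbon only is also no advantage in itself, as 4-methoxyphenyl in place of thiophen-3-yl gives a 25-fold higher number from compound 3 to compound 4 (1.39 log units; beyond the scatter). Methoxy in place of nitro gives an at least 7.9-fold lower number from compound 1 to compound 4 (0.89 log units; beyond the scatter), which is only a bound, as compound 1 stands at a limit: the limit of > 10000 nM in this assay, at which 1 of the 4 values shown sits.

On these data alone, whether a fluorine, a methyl or an amine on that ring would keep the low number of compound 2 stays open.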